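A few compounds are considered here, and "the series" means these few. Any claim that something is new, unique, unknown or untested is made for them only; others in the source may bear on it.

Compound 2 `Cc1ccc(S(=O)(=O)NC(=O)Nc2ccccc2C(=O)/C=C/c2cccc([N+](=O)[O-])c2)cc1` gives 44.5 ug/mL in an ADME assay on the whole organism for cytotoxicity, with Artemia salina as the target, with a stated time of 24 h; a higher number here means that more compound is needed for the effect, a lower number that less compound is needed. Going by the values given here, that is the highest of the three numbers measured so far, though compound 1 `Cc1ccc(S(=O)(=O)NC(=O)Nc2ccccc2C(=O)/C=C/c2ccccc2O)cc1` with 32.3 ug/mL and compound 3 `Cc1ccc(S(=O)(=O)NC(=O)Nc2ccccc2C(=O)/C=C/c2ccc[nH]2)cc1` with 32.1 ug/mL both lie within the scatter of it. Compound 4 `Cc1ccc(S(=O)(=O)NC(=O)Nc2ccccc2C(=O)/C=C/c2ccncc2)cc1` has not yet been measured in this assay. Its difference from compound 2 is pyridin-4-yl in place of 3-nitrophenyl on a double-bonded chain carbon bound to a double-bonded chain carbon. Among the compounds with values here, the steps that bear on this change are a 1.4-fold higher number from compound 1 to compound 2 (0.14 log units; within the scatter), a 1.4-fold lower number from compound 2 to compound 3 (0.14 log units; within the scatter) and a 1.0-fold lower number from compound 1 to compound 3 (0.00 log units; within the scatter), each within the scatter, so three different groups in this place gave no movement beyond the scatter. On that basis compound 4 is expected to show a 1.2-fold lower number from compound 2 to compound 4 (0.09 log units; within the scatter), no step beyond the scatter. The estimate for compound 4 is 36 ug/mL, ranging from 20 ug/mL to 65 ug/mL.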

Compound 4, concentration for half-maximal effect: 16.8 ug/mL
Compound 4: middle estimate off by 2.1-fold (0.33 log units), on the high side; measured number outside the range, below it.
By their numbers in this assay, from the lowest: compounds 4, 3, 1 and 2 (each within the scatter of the next, the first and the last beyond it).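

With pyridin-4-yl in place of 3-nitrophenyl, this place on a double-bonded chain carbon bound to a double-bonded chain carbon shows its first step beyond the scatter in this assay: a 2.6-fold lower number from compound 2 to compound 4 (0.42 log units; beyond the scatter). The other two steps to compound 4 stay within the scatter, at a 1.9-fold lower number from compound 3 to compound 4 (0.28 log units; within the scatter) and a 1.9-fold lower number from compound 1 to compound 4 (0.28 log units; within the scatter). Going by these compounds alone, the group here can therefore move the number, though among the steps to compound 4 only the one from compound 2 shows this, and no measurement given here accounts for it. On these data alone, whether a 4-aminophenyl or a pyridin-3-yl group in this place would fall nearer compound 4 or compound 2 remains open.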